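Swapping the Aromatic Ring on the Amide

The source may report more compounds than this note shows. Statements on the series, on what has been measured and on what is new or still open speak of the compounds shown alone.

Compound 1 `CCCCCCCCCCCC[C@@H](O)[C@H]1CC[C@H]([C@H](O)CCCCCCCCCCNC(=O)c2ccco2)O1` gives 100000 nM
Compound 2 `CCCCCCCCCCCC[C@@H](O)[C@H]1CC[C@H]([C@H](O)CCCCCCCCCCNC(=O)c2ccsc2)O1` gives 100000 nM

In a functional assay on U-251 cells (Homo sapiens) for inhibition, read by colorimetric assay and sulforhodamine B assay, with a stated time of 48 h (a lower number here means a stronger inhibitor of growth, a higher number a weaker inhibitor of growth), compound 2 gives 100000 nM, level with compound 1. Compound 3 `CCCCCCCCCCCC[C@@H](O)[C@H]1CC[C@H]([C@H](O)CCCCCCCCCCNC(=O)c2ccnn2C)O1` carries 1-methyl-1H-pyrazol-5-yl in place of thiophen-3-yl on a carbonyl carbon. Within the data shown here, one measured step bears on this change: no change at the digits printed from compound 1 to compound 2 (within the scatter), where thiophen-3-yl replaced furan-2-yl at that same place. This single step is thin evidence, but it gives no reason to expect a shift beyond the scatter in either direction. The expected result is no change at the digits printed from compound 2 to compound 3 (within the scatter). Compound 3 is estimated at 100000 nM, with an expected range of 40000 nM to 150000 nM.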

Compound 3, concentration for 50% growth inhibition: 100000 nM
Compound 3: middle estimate and measured number agree at the digits printed; the range from low to high includes it.
By their numbers in this assay, from the lowest: compounds 1, 2 and 3 (each within the scatter of the next).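

In this assay the place on the carbonyl carbon now takes 1-methyl-1H-pyrazol-5-yl, a five-membered aromatic ring with 2 hetero atoms, and the result is no change at the digits printed from compound 2 to compound 3 (within the scatter) and likewise no change at the digits printed from compound 1 to compound 3 (within the scatter) for the furan-2-yl compound. All three five-membered aromatic rings shown therefore sit level at this place, whether they carry one hetero atom or two. Nothing measured here accounts for this sameness. Still open, from the compounds shown here alone, is whether a phenyl ring or an amine at this place would move the number, and whether the level result would hold with a shorter chain between the amide and the core.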